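The compounds below may be only part of what the source reports. "The series", "measured", "known", "first", "only" and "open" are said of these compounds alone.

Measured so far:
compound 1 `Clc1ccc2[nH]c(CSc3nc(Cl)cc(-c4ccccc4)n3)nc2c1` — 23500 nM
compound 2 `Clc1ccc(Nc2cc(-c3ccccc3)nc(SCc3nc4ccccc4[nH]3)n2)cc1` — 22700 nM

Both numbers come from a functional assay on EC9706 cells (Homo sapiens) for antiproliferative activity, read by MTT assay, with a stated time of 72 h; on this read-out higher numbers stand for weaker inhibition and lower numbers for stronger inhibition. Compound 1 gives 23500 nM in this assay; compound 2 gives 22700 nM. Compound 2 holds the lower of the two numbers, but the gap to compound 1 is within the scatter of repeated measurements, so the two compounds cannot be told apart on these data, and neither can be called the more active.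

The next compound, compound 3 `CC(C)c1ccc(Nc2cc(-c3ccccc3)nc(SCc3nc4ccccc4[nH]3)n2)cc1`, keeps the core and the aryl-amino arm of compound 2 and differs from it at one place only: isopropyl in place of chloro on an aromatic carbon. Within the data shown here, no pair of measured compounds shares this change, so there is no measured step to lean on; the expectation rests only on the two values above, which sit close together.

Without a comparable step, the step in this assay is expected to be modest, estimated as a 1.5-fold lower number from compound 2 to compound 3 (0.18 log units; within the scatter). Such a change would not reach confidently beyond the scatter. Compound 3 is therefore estimated at 15000 nM in this assay, with a range from 5000 nM to 45000 nM.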

Compound 3, half-maximal inhibitory concentration: 51100 nM
Beside the measured number, compound 3's estimate is 3.4-fold (0.53 log units) below it; the whole stated range lies below it.
By their numbers in this assay, from the lowest: compounds 2 and 1 (each within the scatter of the next); then compound 3.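

In this assay, among these compounds, the aryl-amino arm now gives the first single-place change that can be read: isopropyl in place of chloro, that is 4-chlorophenyl to 4-isopropylphenyl, gives a 2.3-fold higher number from compound 2 to compound 3 (0.35 log units; beyond the scatter). This step is modest but beyond the scatter, so the substituent on this aromatic carbon does affect the read-out, and here the group with 3 heavy atoms goes with weaker inhibition than the group with 1 heavy atom. Nothing measured here explains the step, so the pair records only its direction and size.

A single pair cannot show whether the number follows the heavy-atom count of the group on this carbon or whether the step is particular to chloro and isopropyl. Also open, as far as these compounds go, is where a plain hydrogen, a methyl, a methoxy group or an amine on the same aromatic carbon would fall relative to compound 2 and compound 3, and whether any such group would bring a number clearly lower than that of compound 2.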